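The source may report more compounds than this note shows. Statements on the series, on what has been measured and on what is new or still open speak of the compounds shown alone.

Among the compounds with values here, compound 2 `N/C(=N/NC(CC(=O)c1ccc(-n2ccnc2)cc1)c1ccccc1Br)c1ccccn1` is the lower of the two compounds measured so far in an ADME assay on Vero cells (Chlorocebus sabaeus) for cytotoxicity, read by MTT assay, with a stated time of 72 h; on this read-out lower numbers stand for higher toxicity in this test and higher numbers for lower toxicity in this test: compound 2 gives 29000 nM, while compound 1 `N/C(=N/NC(CC(=O)c1ccc(-n2ccnc2)cc1)c1ccc(F)cc1)c1ccccn1` gives 78800 nM. Within the data shown here, the one step between them, a 2.7-fold lower number from compound 1 to compound 2 (0.43 log units; beyond the scatter), is the only comparison available.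

Compound 3 `N/C(=N/NC(CC(=O)c1ccc(-n2ccnc2)cc1)c1ccc(Cl)cc1)c1ccccn1` is not yet measured. It differs from compound 2 by 4-chlorophenyl in place of 2-bromophenyl on a saturated chain carbon bound to an amine nitrogen and a saturated chain carbon. The 4-chlorophenyl of compound 3 carries the same name pattern as the 4-fluorophenyl of compound 1 rather than the 2-bromophenyl of compound 2, so the step from compound 1 to compound 2 is the nearest guide, and it was modest. Since that step ran downward, a return in the other direction, toward the number of compound 1, is expected for compound 3, though not necessarily all the way. Among the measured compounds shown here, the halogen itself also changes between compound 1 and compound 3, and no measured step covers that. The expected step in this assay from compound 2 to compound 3 is a 1.7-fold higher number from compound 2 to compound 3 (0.24 log units; within the scatter). Compound 3 is therefore estimated at 50000 nM, with a range from 20000 nM to 120000 nM.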

Compound 3, half-maximal cytotoxic concentration: 78800 nM
For compound 3 the middle estimate is 1.6-fold (0.20 log units) below the measured one, and the stated range covers the measured number.
By their numbers in this assay, from the lowest: compound 2; then compounds 1 and 3 (each within the scatter of the next).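

In this assay, 4-chlorophenyl in place of 2-bromophenyl on the saturated chain carbon gives a 2.7-fold higher number from compound 2 to compound 3 (0.43 log units; beyond the scatter), so compound 2 now stands apart from both compounds that carry a 4-halogenated phenyl, and not only from compound 1. Chloro in place of fluoro on the aromatic carbon, a change that could not be read from the earlier compounds, gives no change at the digits printed from compound 1 to compound 3 (within the scatter), so among the compounds shown this exchange of halogens leaves the half-maximal cytotoxic concentration unmoved. Nothing available explains either step.

The step from compound 2 to compound 3 changes the halogen and its place on the ring together, so the compounds shown cannot separate the two; a 2-chlorophenyl or a 4-bromophenyl group at the same chain carbon would bear on that question. They also leave open whether the flat result for fluoro and chloro would hold for an unsubstituted phenyl, a 4-methoxyphenyl or a 4-aminophenyl group there.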